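Morpholinyl replaces diisopropylamino on the dithiocarbamate thiocarbonyl

The source may hold more compounds than are shown below. What is called first, only, known or untested is meant among the compounds shown, and "the series" means these compounds.

Measured so far in a functional assay on LM7 cells (Homo sapiens) for antiproliferative activity, read by MTT assay, with a stated time of 72 h; on this read-out lower numbers stand for stronger inhibition and higher numbers for weaker inhibition:
compound 1 `O=c1cc(CSC(=S)N2CCCCC2)oc2cc(Cl)ccc12` gives 13800 nM
compound 2 `O=c1c(CSC(=S)N2CCCC2)coc2ccccc12` gives 6000 nM
compound 3 `CC(C)N(C(=S)SCc1cc(=O)c2ccc(Cl)cc2o1)C(C)C` gives > 30000 nM

Compound 3 reaches only the limit of the assay, (the limit of > 30000 nM in this assay, at which 1 of the 3 values shown sits), so no number is known for it. Compound 4 `O=c1cc(CSC(=S)N2CCOCC2)oc2cc(Cl)ccc12` differs from compound 3 by morpholin-4-yl in place of diisopropylamino on a thiocarbonyl carbon. For the measured compounds named here, the one measured step that bears on this change is an at least 2.1-fold higher number from compound 1 to compound 3 (0.33 log units; beyond the scatter), where a ring amine on the thiocarbonyl carbon gave the lower number. Returning to a six-membered ring amine is therefore expected to lower the number again, by about an at least 2.0-fold lower number from compound 3 to compound 4 (0.30 log units; that floor lies within the scatter). Compound 4 is estimated at 15000 nM, within the range 6000 nM to 40000 nM.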

Compound 4, half-maximal inhibitory concentration: > 25000 nM
Compound 4 was reported as a limit (the forecaster's own chance of this, stated with the estimate: 30%); middle value at least 1.6-fold (0.22 log units) from the limit.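

In this assay compound 4 stands only as a limit, not a number: the limit of > 25000 nM in this assay, at which 1 of the 4 values shown sits. Both compound 3 and compound 4 are limits, and the step between them cannot be read. Exchanging piperidin-1-yl for morpholin-4-yl on the thiocarbonyl carbon gives an at least 1.8-fold higher number from compound 1 to compound 4 (0.25 log units; that floor lies within the scatter), so a six-membered ring amine at this place does not by itself secure a measured number. The compounds shown leave open where compound 4 truly lies. They also leave open whether a piperazin-1-yl or a dimethylamino group on this carbon would give a number on the same core.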